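A few compounds are considered here, and "the series" means these few. Any claim that something is new, unique, unknown or untested is made for them only; others in the source may bear on it.

For the measured compounds named here, compound 1 `CCOC(=O)C1=C(C)N/C(=C/c2cc(C)n(-c3ccc(CN(C)C)cc3)c2C)C1=O` is the more lipophilic of the two compounds measured so far. In a physicochemical assay for lipophilicity, read by HPLC, at pH 7.4 (a lower number here means a more polar compound, a higher number a more lipophilic compound), compound 1 gives 8.3, the highest of the two numbers; its nearest neighbour is compound 2 `CCOC(=O)C1=C(C)N/C(=C/c2cc(C)n(-c3ccncc3)c2C)C1=O`, which in this assay gives 3.2. Going by the values given here, the only step recorded, a number 5.10 log units lower from compound 1 to compound 2 (beyond the scatter), was a large one, beyond the scatter.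

Compound 3 `CCOC(=O)C1=C(C)N/C(=C/c2cc(C)n(-c3cccnc3)c2C)C1=O` differs from compound 1 by the change (pyridin-3-yl in place of 4-((dimethylamino)methyl)phenyl on an aromatic nitrogen). The step from compound 1 to compound 2 bears directly on it: both changes exchange the same leaving group for a pyridinyl group at the same aromatic nitrogen, and that step was large. A step of similar size and the same direction is therefore expected, a number 4.90 log units lower from compound 1 to compound 3 (beyond the scatter), well beyond the scatter. Compound 3 is estimated to give 3.4, with a likely range from 2.7 to 4.1.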

Compound 3, distribution coefficient: 2.1
The estimate for compound 3 lay 1.30 log units above the measured number, outside the stated range (below it).
By their numbers in this assay, from the lowest: compound 3; then compound 2; then compound 1.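

With pyridin-3-yl on the aromatic nitrogen in place of 4-((dimethylamino)methyl)phenyl, the reading in this assay shows a number 6.20 log units lower from compound 1 to compound 3 (beyond the scatter) and so the large fall first seen with pyridin-4-yl now appears with a second pyridinyl group. The two pyridinyl groups do not read alike, since pyridin-3-yl in place of pyridin-4-yl at this same position gives a number 1.10 log units lower from compound 2 to compound 3 (beyond the scatter) and the exact pyridinyl group therefore matters here. No measurement at hand explains this gap between the two groups. The compounds shown leave open how much of the large fall goes with the loss of the dimethylaminomethyl group and how much with the ring nitrogen of the pyridinyl groups, a question that a plain phenyl group on this nitrogen would address. On these data alone, how a pyridin-2-yl group would read at this position also remains open.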